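A few compounds are considered here, and "the series" means these few. Any claim that something is new, unique, unknown or untested is made for them only; others in the source may bear on it.

Series notes on the shared core. In an assay for inhibition of histone-lysine N-methyltransferase EZH2 variant Y641N (Homo sapiens), read by scintillation counting, with a stated time of 60 min, in the presence of a further agent that is not named here (on this read-out higher numbers stand for weaker inhibition and lower numbers for stronger inhibition), compound 2 `COc1cc(C)[nH]c(=O)c1CN1CCc2c(Cl)cc(-c3c(C)noc3C)c(Cl)c2C1=O` gives 0.15 nM. Compound 1 `Cc1cc(C)c(CN2CCc3c(Cl)cc([C@H](CO)[C@H]4CCOC4)c(Cl)c3C2=O)c(=O)[nH]1` gives 0.24 nM in this assay, a number within the scatter of that of compound 2, so the two cannot be told apart on these data. Compound 3 `COC(c1cc(Cl)c2c(c1Cl)C(=O)N(Cc1c(C)cc(C)[nH]c1=O)CC2)C1CCOCC1` has no single number in this assay: its entries read 310 nM; 0.1 nM (2 entries), and the spread among them the several entries of compound 3 in this assay, 310 nM; 0.1 nM (2 entries) lies far beyond the scatter, so compound 3 is set aside for comparison. Compound 2 thus stands together with compound 1 at the low end of what has been measured.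

Compound 4 `COc1cc(C)[nH]c(=O)c1CN1CCc2c(Cl)cc([C@H](O)C3COC3)c(Cl)c2C1=O` is next to be measured. It differs from compound 2 by a group of 6 heavy atoms (4 carbon, 2 oxygen; one four-membered non-aromatic ring with 1 hetero atom) in place of a group of 7 heavy atoms (5 carbon, 1 nitrogen, 1 oxygen; one five-membered aromatic ring with 2 hetero atoms), on an aromatic carbon. Going by the values given here, no step between measured compounds matches this change. Compound 1, which likewise carries a hydrogen-bond donor and a non-aromatic ring on that carbon, gives 0.24 nM, so the change is expected to cost little. The step from compound 2 to compound 4 is estimated at a 2.3-fold higher number from compound 2 to compound 4 (0.37 log units; beyond the scatter), within the scatter or slightly weaker. Compound 4 is expected at 0.35 nM, in the range 0.1 nM to 1.5 nM.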

Compound 4, inhibition constant in the histone-lysine N-methyltransferase EZH2 assay: 1.5 nM
Beside the measured number, compound 4's estimate is 4.3-fold (0.63 log units) below it; the range from low to high includes it.
By their numbers in the histone-lysine N-methyltransferase EZH2 assay, from the lowest: compounds 2 and 1 (each within the scatter of the next); then compound 4.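

In the histone-lysine N-methyltransferase EZH2 assay the aromatic carbon ortho to a chloro group and para to a fused ring proves sensitive to what it carries: exchanging 3,5-dimethyl-1,2-oxazol-4-yl for the group with one four-membered non-aromatic ring with 1 hetero atom gives a 10-fold higher number from compound 2 to compound 4 (1.00 log units; beyond the scatter), a modest step but one that can be read. In the histone-lysine N-methyltransferase EZH2 assay compound 2 gives 0.15 nM and compound 4 gives 1.5 nM. In a physicochemical assay for solubility, measured as kinetic solubility (a higher number here means a more soluble compound, a lower number a less soluble compound), compound 2 gives 384000 nM and compound 4 gives 234000 nM. In the physicochemical assay the same exchange gives a 1.6-fold lower number from compound 2 to compound 4 (0.22 log units; within the scatter), so this pair shows a separation in inhibition but none in kinetic solubility. Nothing measured here accounts for the step in inhibition, and the entries available offer no explanation for it.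

On these data alone, with one exchange read at this position, it stays open whether the step follows from losing the five-membered aromatic ring, from the added hydrogen-bond donor, or from the four-membered ring as such. The compounds shown also do not tell how an amine or a carboxylic acid on this aromatic carbon would read against 3,5-dimethyl-1,2-oxazol-4-yl in either measurement.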